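The compounds below may be only part of what the source reports. "The series", "measured", "known", "first", "only" and "open" are said of these compounds alone.

Measured so far:
compound 1 `O=C(Nc1cccc(-n2cc(-c3ccncc3)c(-c3ccc(Cl)c(O)c3)n2)c1)Nc1ccc(Cl)c(Cl)c1` — > 32500 nM
compound 2 `COc1cc(-c2nn(-c3cccc(NC(=O)c4cccc(C(F)(F)F)c4)c3)cc2-c2ccncc2)ccc1Cl` — > 50000 nM

In a functional assay on OVCAR-8 cells (Homo sapiens) for inhibition, read by sulforhodamine B assay, with a stated time of 48 h (a lower number here means a stronger inhibitor of growth, a higher number a weaker inhibitor of growth), compound 1 gives > 32500 nM, which is a limit of the assay and not a number (the limit of > 32500 nM in this assay, at which 1 of the 2 values shown sits). Compound 2 likewise sits at a limit, > 50000 nM (the limit of > 50000 nM in this assay, at which 1 of the 2 values shown sits). Neither value places one compound relative to the other. Compound 3 `O=C(Nc1cccc(-n2cc(-c3ccncc3)c(-c3ccc(Cl)c(O)c3)n2)c1)Nc1ccc(Cl)c(C(F)(F)F)c1` differs from compound 1 by trifluoromethyl in place of chloro on an aromatic carbon. Within the data shown here, no step between measured compounds is available. The step in this assay is expected to be a step that the limit leaves unreadable from compound 1 to compound 3, none beyond the scatter in either direction. Compound 3 is estimated at 40000 nM, with a range from 12000 nM to 120000 nM, and is most likely reported again only as a limit.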

Compound 3, concentration for total growth inhibition: 2280 nM
Beside the measured number, compound 3's estimate is 18-fold (1.24 log units) above it; the measured number lies below the stated range.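

In this assay, the change from 3,4-dichlorophenyl to 4-chloro-3-(trifluoromethyl)phenyl gives an at least 14-fold lower number from compound 1 to compound 3 (1.15 log units; beyond the scatter). This position is therefore sensitive: with the shared core unchanged, trifluoromethyl in place of chloro yields a measurable number rather than a limit. The step has only a lower bound, as compound 1 sits at a limit: the limit of > 32500 nM in this assay, at which 1 of the 3 values shown sits.

The compounds shown leave open why this replacement has such an effect. They also leave open whether a nitrile or a tert-butyl group at the same carbon would give a comparable result.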